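The source may report more compounds than this note shows. Statements on the series, on what has been measured and on what is new or still open speak of the compounds shown alone.

Working notes on the series in a functional assay on SW480 cells (Homo sapiens) for cytotoxicity, read by sulforhodamine B assay, with a stated time of 48 h; on this read-out higher numbers stand for weaker inhibition and lower numbers for stronger inhibition.

Three compounds carry numbers. Compound 1, `COc1ccc(-c2cc(C(=O)/C=C/c3cccc(OC)c3OC)ccc2N)cc1OC`, gives 8330 nM. Compound 2, `O=C(/C=C/c1cccc(Br)c1)c1cccc(-c2cccc(F)c2)c1`, gives 8610 nM. Compound 3, `O=C(/C=C/c1ccc(Cl)cc1)c1cccc(-c2cccc(F)c2)c1`, gives 16900 nM, the highest of the three numbers; the gap to compound 2 is within the scatter, the gap to compound 1 is beyond it, so compound 3 reads as a weaker inhibitor than compound 1 only.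

The next compound, compound 4, `O=C(/C=C/c1ccc(Br)cc1)c1cccc(-c2cccc(F)c2)c1`, differs from compound 3 in one place: bromo in place of chloro on an aromatic carbon.

For the measured compounds named here, only one measured step touches a halogen on this ring, a 2.0-fold higher number from compound 2 to compound 3 (0.29 log units; within the scatter), and it changes both the halogen and its position, so it does not isolate the chloro-to-bromo exchange at the same site. Going by the values given here, no pair in the set shows that exchange alone. Among the compounds with values here, a halogen of the same kind swapped for one a row down, at the same position, has no precedent here beyond the fact that compound 2 and compound 3 sit within the scatter of each other.

The expectation is therefore a step of a 1.4-fold lower number from compound 3 to compound 4 (0.15 log units; within the scatter), within the scatter, with a slight lean toward a lower number. Compound 4 is estimated at 12000 nM, between 5000 nM and 30000 nM.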

Compound 4, half-maximal inhibitory concentration: 18200 nM
Estimate against measurement, compound 4: 1.5-fold (0.18 log units) below, within the range that was stated.
By their numbers in this assay, from the lowest: compounds 1, 2, 3 and 4 (each within the scatter of the next, the first and the last beyond it).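

In this assay, the exchange of chloro for bromo on the aromatic carbon is now seen on its own, as a 1.1-fold higher number from compound 3 to compound 4 (0.03 log units; within the scatter), and it lies within the scatter, so the two halogens cannot be told apart at this position. For the compounds shown here, with bromo held constant, a 2.1-fold higher number from compound 2 to compound 4 (0.33 log units; beyond the scatter) is a modest step beyond the scatter, giving the first reading of the halogen's place on the ring that is free of a change of halogen, with 4-bromophenyl on the higher number and 3-bromophenyl on the lower. No measurement offered here bears on the reason for this small shift with position, so the numbers stand as a description only.

From the compounds shown here alone, whether a group of another kind at the same place, such as a nitrile, a carboxylic acid or an amine, would move the number beyond the scatter remains open. Also open, going by these compounds, is whether the modest step between 4-bromophenyl and 3-bromophenyl recurs with chloro, or with a different group in place of the fluorophenyl part of the shared core.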